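Working notes: amino in place of hydrogen on the core

The source may hold more compounds than are shown below. What is called first, only, known or untested is meant among the compounds shown, and "the series" means these compounds.

Measured so far:
compound 1 `ClCc1ccccc1Cn1cnc2c(Cl)nc(Cl)nc21`, 1540 nM
compound 2 `ClCc1ccccc1Cn1cnc2c(Cl)ncnc21`, 8910 nM
compound 3 `ClCc1cccc(Cn2cnc3c(Cl)nc(Cl)nc32)c1`, 6450 nM

In a functional assay on OVCAR-3 cells (Homo sapiens) for cytotoxicity, read by sulforhodamine B assay, with a stated time of 48 h (on this read-out lower numbers stand for higher toxicity in this test and higher numbers for lower toxicity in this test), compound 2 gives the highest of the three numbers; compound 3 sits within the scatter of it, while compound 1 is well apart from it, as the step of a 5.8-fold higher number from compound 1 to compound 2 (0.76 log units; beyond the scatter) shows. Compound 4 `Nc1nc(Cl)c2ncn(Cc3ccccc3CCl)c2n1` is compound 2 with amino in place of hydrogen on an aromatic carbon, that is, on the same aromatic carbon of the core that carries chloro in compound 1 and hydrogen in compound 2. Among the compounds with values here, the only measured step that bears on this change is a 5.8-fold higher number from compound 1 to compound 2 (0.76 log units; beyond the scatter), which concerns the same carbon: taking away the chloro there gave a modest rise in the number. Within the data shown here, no measured pair shows what an amino group does at this carbon, so the direction of the step cannot be read from the data; the size seen for the chloro-to-hydrogen step is taken as the scale of what may happen. Compound 4 is therefore expected to come out at about 6000 nM in this assay, between 1800 nM and 20000 nM, an estimated step of a 1.5-fold lower number from compound 2 to compound 4 (0.17 log units; within the scatter).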

Compound 4, concentration lethal to 50% of the cells: 46800 nM
Beside the measured number, compound 4's estimate is 7.8-fold (0.89 log units) below it; the measured number lies above the stated range.
By their numbers in this assay, from the lowest: compound 1; then compounds 3 and 2 (each within the scatter of the next); then compound 4.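

Amino at this carbon moves the number up, not down, with a 5.3-fold higher number from compound 2 to compound 4 (0.72 log units; beyond the scatter). Until now the carbon had shown only the rise on losing chloro, and amino now extends the series in the same direction, so that chloro, hydrogen and amino stand in order of rising number. Across the whole range at this carbon, a 30-fold higher number from compound 1 to compound 4 (1.48 log units; beyond the scatter), which makes this one position able to shift the number far beyond the scatter, with amino giving the lowest toxicity in this test of the three groups compared here.

As far as these compounds go, whether a methylamino or a methoxy group at this carbon would also raise the number remains open, as does the effect of amino when the chloromethyl group sits as in compound 3. No measurement in hand accounts for these steps.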